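This account rests on a few compounds, and the source may have more. Where it says the series, first, only, none or still open, it means among the compounds named here.

Of the compounds shown here, two have been measured in a functional assay on MCF7 cells (Homo sapiens) for antiproliferative activity; a lower number here means a stronger inhibitor, a higher number a weaker inhibitor. Compound 1 `COC1=C(OCc2ccc([N+](=O)[O-])cc2)C(=O)O/C1=C/Cn1cnc2c(Cl)ncnc21` gives 14200 nM, a measured number. Compound 2 `COC1=C(OC)C(O)(CCn2cnc3c(Cl)ncnc32)OC1=O` gives > 120000 nM, and this value is a limit of the assay, not a number. Compound 2 therefore has no exact position on the scale and is known only through that limit.

Compound 3 `COC1=C(OC)C(O)(CCn2cnc3c(N)ncnc32)OC1=O` keeps the frame of compound 2 and changes one group: amino in place of chloro on an aromatic carbon, (amino in place of chloro on an aromatic carbon). Within the data shown here, no measured pair shows what this exchange does in this assay. Compound 1 and compound 2 differ in more than one place, so their values do not isolate it.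

The expectation therefore starts from compound 2 at > 120000 nM, which is again only a limit. No clear gain in potency is expected, and compound 3 will probably stay weak, quite possibly reported only as a limit. The expected change, a step that the limit leaves unreadable from compound 2 to compound 3, is a modest one with no firm direction. For compound 3 the estimate is 140000 nM, with an expected range from 50000 nM to 300000 nM.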

Compound 3, half-maximal inhibitory concentration: > 120000 nM
Compound 3: a limit, no number; the forecaster's own chance of this, stated with the estimate: 70%; the middle value lies beyond the limit too.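

In this assay compound 3 gives > 120000 nM, which is a limit and not a number. Among these compounds, compound 2 also stands only at a limit, so no step between compound 2 and compound 3 can be read: the limit of > 120000 nM in this assay, at which 2 of the 3 values shown sit. The compounds shown leave open what amino in place of chloro on an aromatic carbon does in this assay.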